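The source may hold more compounds than are shown below. What is called first, only, known or untested is meant among the compounds shown, and "the series" means these compounds.

Compound 1 `COc1ccc(-c2cc(/C=C/C(=O)c3ccc(OC)c(OC)c3)[nH]n2)cc1`: 3350 nM
Compound 2 `COc1cc(-c2cc(/C=C/C(=O)c3ccc(Cl)c(Cl)c3)[nH]n2)cc(OC)c1OC`: > 100000 nM
Compound 3 `COc1ccc(-c2cc(/C=C/C(=O)c3ccc(N)cc3)[nH]n2)cc1`: 2940 nM

All three were tested in a functional assay on UACC-62 cells (Homo sapiens) for inhibition, read by sulforhodamine B assay, with a stated time of 48 h; on this read-out higher numbers stand for weaker inhibition of growth and lower numbers for stronger inhibition of growth. Compound 1 gives 3350 nM and compound 3 gives 2940 nM, two values that lie within the usual scatter of each other. Compound 2 stands apart on the numbers shown: in this assay compound 2 gives only > 100000 nM, which is a limit of the assay and not a number, the compound sitting at the limit of > 100000 nM in this assay, at which 1 of the 3 values shown sits.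

The step followed here leads from compound 2 to compound 4 `COc1cc(-c2cc(/C=C/C(=O)c3ccc(F)c(F)c3)[nH]n2)cc(OC)c1OC`, which has not yet been measured in this assay. The change is 3,4-difluorophenyl in place of 3,4-dichlorophenyl on a carbonyl carbon. Within the data shown here, no pair of measured compounds differs in one place, so there is no measured step to set the size of this change, and the present account rests on compound 2 alone. Because compound 2 sits at the limit of > 100000 nM in this assay, at which 1 of the 3 values shown sits, only a clear gain in inhibition of growth would bring compound 4 to a measured number. The step from compound 2 to compound 4 is expected to be an at least 1.4-fold lower number from compound 2 to compound 4 (0.15 log units; that floor lies within the scatter), a shift toward stronger inhibition of growth that is not expected to go clearly beyond the scatter. Compound 4 is estimated at 70000 nM, with a range from 15000 nM to 300000 nM.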

Compound 4, concentration for total growth inhibition: 7440 nM
Estimate against measurement, compound 4: 9.4-fold (0.97 log units) above, and the stated range ends above it.
By their numbers in this assay, from the lowest: compounds 3 and 1 (each within the scatter of the next); then compound 4. At a limit, above all of these: compound 2.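

In this assay, among these compounds, 3,4-difluorophenyl in place of 3,4-dichlorophenyl on a carbonyl carbon gives an at least 13-fold lower number from compound 2 to compound 4 (1.12 log units; beyond the scatter), a shift toward stronger inhibition of growth and the first step in this set that changes a single place. Compound 2 is held at a limit of the assay and not at a number: the limit of > 100000 nM in this assay, at which 1 of the 4 values shown sits. Among the compounds shown here, the earlier compounds differed from one another in more than one place and could not isolate this position, whereas this pair shows that the halogens on this phenyl group alone can carry a compound from that limit to a measured value, although the true size of the step remains unknown and only its lower bound can be read.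

From the compounds shown here alone, what remains open is whether the gain is specific to the 3,4-difluorophenyl group, or whether a single fluorine, a trifluoromethyl group, a nitrile or an unsubstituted phenyl at this place would give a similar value on the core of compound 4. The compounds shown also leave open whether the same exchange would have a step of similar size on the core of compound 1.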